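A few compounds are considered here, and "the series" means these few. Any claim that something is new, unique, unknown or untested is made for them only; others in the source may bear on it.

In a physicochemical assay for solubility, read by HPLC, in phosphate buffer, measured as kinetic solubility, at pH 7.4 (a higher number here means a more soluble compound, a lower number a less soluble compound), compound 1 (`CCC(=O)c1cc(-c2ccc(S(N)(=O)=O)cc2)n(-c2cccc(Cl)c2)n1`) gives 6900 nM and compound 2 (`CCC(=O)c1cc(-c2ccc(S(N)(=O)=O)cc2)n(-c2ccc(C(F)(F)F)cn2)n1`) gives 99400 nM. Compound 2 therefore holds the higher of the two numbers, and its gap to compound 1 lies beyond the scatter. Among the compounds with values here, no measured pair differs in one place only, so this gap gives no size for any single exchange. Compound 3 (`CCC(=O)c1cc(-c2ccc(S(N)(=O)=O)cc2)n(-c2ccc(Cl)cn2)n1`) departs from compound 2 by one group: chloro in place of trifluoromethyl on an aromatic carbon, two atoms from the ring nitrogen, para to a large group (chloro in place of trifluoromethyl on an aromatic carbon). Within the data shown here, with no measured step to draw on, a small fall in this assay is expected, close to the scatter, starting from compound 2 at 99400 nM. The estimated change is a 1.8-fold lower number from compound 2 to compound 3 (0.26 log units; within the scatter). For compound 3 the expected value is 55000 nM, with an estimated range of 18000 nM to 130000 nM.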

Compound 3, solubility: 33700 nM
Estimate against measurement, compound 3: 1.6-fold (0.21 log units) above; low and high end bracket the measured number.
By their numbers in this assay, from the lowest: compound 1; then compound 3; then compound 2.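

In this assay, the exchange at this aromatic carbon, two atoms from the ring nitrogen and para to a large group, now has a size: chloro in place of trifluoromethyl gives a 2.9-fold lower number from compound 2 to compound 3 (0.47 log units; beyond the scatter), so the group at this carbon moves the read-out beyond the scatter. On the aromatic nitrogen of the core, 5-chloropyridin-2-yl in place of 3-chlorophenyl gives a 4.9-fold higher number from compound 1 to compound 3 (0.69 log units; beyond the scatter), a second step beyond the scatter, although both of these groups carry chloro. Nothing at hand accounts for either step.

From the compounds shown here alone, whether other groups on this aromatic carbon, such as a nitrile, a methoxy group or an amine, would read above compound 2 or below compound 3 stays open. Going by these compounds, how the second step divides between the ring nitrogen and the place of the chloro also stays open.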